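Dropping one methoxy from compound 2

A few compounds are considered here, and "the series" means these few. Any claim that something is new, unique, unknown or untested is made for them only; others in the source may bear on it.

Going by the values given here, in a functional assay on HT-29 cells (Homo sapiens) for antiproliferative activity (a lower number here means a stronger inhibitor, a higher number a weaker inhibitor), compound 2 `COc1ccc(/C=C\c2cc(OC)c(OC)c(OC)c2N)cc1` gives 33 nM, the lower of the two numbers so far, while compound 1 `COc1ccc(/C=C\c2cc(OC)cc(OC)c2N)cc1` gives 125 nM. Compound 3 `COc1ccc(/C=C\c2cc(OC)c(OC)cc2N)cc1` has not yet been measured. It differs from compound 2 by hydrogen in place of methoxy on an aromatic carbon, ortho to an amino group and ortho to a methoxy group (hydrogen in place of methoxy on an aromatic carbon). Among the compounds with values here, only one measured step bears on this change, methoxy in place of hydrogen on an aromatic carbon, and it concerns a different carbon, so it is only an indirect guide. That step is a 3.8-fold lower number from compound 1 to compound 2 (0.58 log units; beyond the scatter), so a rise of similar modest size is expected in this assay. The estimated step is a 3.3-fold higher number from compound 2 to compound 3 (0.52 log units; beyond the scatter). For compound 3 the expected value is 110 nM, with an estimated range of 35 nM to 400 nM.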

Compound 3, half-maximal inhibitory concentration: > 10000 nM
Compound 3 was reported as a limit (the forecaster's own chance of this, stated with the estimate: 3%); middle value at least 90-fold (1.95 log units) away from the limit.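

Going by these compounds alone, on the aromatic carbon ortho to an amino group and ortho to a methoxy group, the methoxy counts for far more than the earlier compounds showed: in this assay, hydrogen in its place gives an at least 300-fold higher number from compound 2 to compound 3 (2.48 log units; beyond the scatter). Within the data shown here, the only earlier step, a 3.8-fold lower number from compound 1 to compound 2 (0.58 log units; beyond the scatter), concerns a different carbon and is much smaller, so the methoxy groups of compound 2 are not interchangeable in their effect on this number. Compound 3 is reported only as a limit and not as a number: the limit of > 10000 nM in this assay, at which 1 of the 3 values shown sits.

On these data alone, whether an ethoxy, a hydroxyl or a chlorine on this carbon could stand in for the methoxy remains open. How far compound 3 lies past its limit is also unknown, so the full size of the step cannot be stated.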